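Series notes: compound 1 to compound 4

This account rests on a few compounds, and the source may have more. Where it says the series, first, only, none or still open, it means among the compounds named here.

compound 1 `CC(C)C(/C=C1\NC(=O)NC1=O)c1ccc(-c2ccc3cccc(F)c3c2)[nH]c1=O`: 10700 nM
compound 2 `CC(C)C(/C=C1\OC(=O)NC1=O)c1cc(Cl)c(-c2ccc3cccc(F)c3c2)[nH]c1=O`: 21500 nM
compound 3 `CC(C)/C(=C1/SC(=O)NC1=O)c1ccc(-c2ccc3cccc(F)c3c2)[nH]c1=O`: 23300 nM

All three values come from a physicochemical assay for solubility, in phosphate buffer, measured as kinetic solubility; a higher number here means a more soluble compound, a lower number a less soluble compound. Compound 1 and compound 2 lie within the scatter of each other, while compound 3 carries a higher number than compound 1, with the gap beyond the scatter. Compound 4 `CC(C)C(c1ccc(-c2ccc3cccc(F)c3c2)[nH]c1=O)C1C(=O)NC(=O)N1C` is not yet measured. Relative to compound 1 it differs as follows: a group of 8 heavy atoms (4 carbon, 2 nitrogen, 2 oxygen; one five-membered non-aromatic ring with 2 hetero atoms) in place of a group of 8 heavy atoms (4 carbon, 2 nitrogen, 2 oxygen; one five-membered non-aromatic ring with 2 hetero atoms), on a saturated chain carbon bound to an aromatic carbon and a saturated chain carbon. The entering group is 3-methyl-2,5-dioxoimidazolidin-4-yl, on a saturated chain carbon bound to an aromatic carbon and a saturated chain carbon. For the measured compounds named here, no measured pair isolates this change, so the expectation rests on the narrow spread of the series, which reaches compound 3 at 23300 nM. A modest upward move is expected, a 2.3-fold higher number from compound 1 to compound 4 (0.37 log units; beyond the scatter). Compound 4 is estimated at 25000 nM, with an expected range of 10000 nM to 65000 nM.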

Compound 4, solubility: 17900 nM
The estimate for compound 4 lay 1.4-fold (0.15 log units) above the measured number; low and high end bracket the measured number.
By their numbers in this assay, from the lowest: compounds 1, 4, 2 and 3 (each within the scatter of the next, the first and the last beyond it).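

In this assay, placing 3-methyl-2,5-dioxoimidazolidin-4-yl on the saturated chain carbon bound to an aromatic carbon and a saturated chain carbon gives a 1.7-fold higher number from compound 1 to compound 4 (0.22 log units; within the scatter) and so provides no separation between the two compounds. The exchange alters the counts of double bonds outside aromatic rings and of hydrogen-bond donors, yet the two numbers cannot be told apart. No measurement at hand offers an explanation for this result. Open, going by these compounds, is whether an amine or a carboxylic acid at this position, in place of the ring, would move the number beyond the scatter.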